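Compound 4: another amide at the assay limit?

The source may report more compounds than this note shows. Statements on the series, on what has been measured and on what is new or still open speak of the compounds shown alone.

Within the data shown here, in a functional assay on MDA-MB-231 cells (Homo sapiens) for inhibition, read by MTT assay, with a stated time of 48 h (on this read-out higher numbers stand for weaker inhibition and lower numbers for stronger inhibition), compound 1 (`Cn1c(/C=C2\SC(=O)N(CC(=O)Nc3cc(C(C)(C)C)on3)C2=O)nc2ccccc21`) gives 33800 nM, the only true number so far. Compound 2 (`Cn1c(/C=C2\SC(=O)N(CC(=O)N3CCOCC3)C2=O)nc2ccccc21`) reads > 50000 nM, which is a limit of the assay. Compound 3 (`Cn1c(/C=C2\SC(=O)N(CC(=O)N3CCCC3)C2=O)nc2ccccc21`) reads > 50000 nM, also a limit, so its position is known only as a limit. This sits within the wider picture of the limit of > 50000 nM in this assay, at which 2 of the 3 values shown sit.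

Compound 4 (`CC1CN(C(=O)CN2C(=O)S/C(=C\c3nc4ccccc4n3C)C2=O)CC(C)O1`) carries 2,6-dimethylmorpholin-4-yl in place of pyrrolidin-1-yl on a carbonyl carbon.

Among the measured compounds shown here, three measured steps bear on this change. The swap most like it, a step that the two limits leave unreadable from compound 2 to compound 3, cannot be sized. The other two, an at least 1.4-fold higher number from compound 1 to compound 2 (0.17 log units; that floor lies within the scatter) and an at least 1.4-fold higher number from compound 1 to compound 3 (0.17 log units; that floor lies within the scatter), have floors that stay within the scatter. No step beyond the scatter is therefore expected, and another limit reading is the likeliest outcome. The expected step is a step that the limit leaves unreadable from compound 3 to compound 4, an estimate with little numerical support. For compound 4 the estimated value is 60000 nM, with an expected range of 25000 nM to 150000 nM.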

Compound 4, half-maximal inhibitory concentration: > 50000 nM
Compound 4: only a limit was reported; the forecaster's own chance of this, stated with the estimate: 80%; the middle value does not contradict the limit.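

In this assay compound 4 reads > 50000 nM, which is a limit of the assay and not a number. With 2,6-dimethylmorpholin-4-yl on the carbonyl carbon, a third ring amide joins compound 2 and compound 3 at the same reading: the limit of > 50000 nM in this assay, at which 3 of the 4 values shown sit. Among these compounds, the only readable new step is an at least 1.4-fold higher number from compound 1 to compound 4 (0.17 log units; that floor lies within the scatter), and the steps among the three ring amides cannot be read.

Compound 1, at 33800 nM, remains the only true number, and the compounds shown do not separate the contribution of its amide hydrogen from that of the rest of (5-(tert-butyl)-1,2-oxazol-3-yl)amino. From the compounds shown here alone, a phenylamino or tert-butylamino group on the same carbonyl carbon would bear on that question, and whether either gives a true number in this assay remains open.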